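The source may report more compounds than this note shows. Statements on the series, on what has been measured and on what is new or still open speak of the compounds shown alone.

In a functional assay on K562 cells (Homo sapiens) for cytotoxicity, read by MTT assay, with a stated time of 48 h (a higher number here means a weaker inhibitor, a lower number a stronger inhibitor), three compounds share a core and differ only in the aromatic group on a saturated chain carbon bound to an amine nitrogen in a ring. Compound 1 `Cc1cccc(CN2CCN(C(=O)CN[C@H]3CCN(S(=O)(=O)Cc4ccccc4)C3)CC2)c1`, carrying 3-methylphenyl, gives 11300 nM. Compound 2 `O=C(CN[C@H]1CCN(S(=O)(=O)Cc2ccccc2)C1)N1CCN(Cc2ccc(Cl)cc2)CC1`, carrying 4-chlorophenyl, gives 9200 nM. The step here is a 1.2-fold lower number from compound 1 to compound 2 (0.09 log units; within the scatter), so these two cannot be told apart. Compound 3 `Cc1cc(C)c(CN2CCN(C(=O)CN[C@H]3CCN(S(=O)(=O)Cc4ccccc4)C3)CC2)c(C)c1`, carrying 2,4,6-trimethylphenyl, gives 3300 nM, the lowest number of the three, and the steps to it are a 3.4-fold lower number from compound 1 to compound 3 (0.53 log units; beyond the scatter) and a 2.8-fold lower number from compound 2 to compound 3 (0.45 log units; beyond the scatter).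

Compound 4 `O=C(CN[C@H]1CCN(S(=O)(=O)Cc2ccccc2)C1)N1CCN(Cc2c(F)cccc2Cl)CC1` has not yet been measured. Its change from compound 2 is this: 2-chloro-6-fluorophenyl in place of 4-chlorophenyl on a saturated chain carbon bound to an amine nitrogen in a ring. Read one bond further out, this is 4-chlorobenzyl to 2-chloro-6-fluorobenzyl. Among the measured compounds shown here, no measured compound carries this new group, so the guidance is indirect. For the measured compounds named here, compound 3 is the only measured compound with more than one substituent on that ring, and it alone stands clearly apart, though three compounds make a thin basis. Its methyl groups also differ from the halogens in the new group, so only part of that modest step is expected to carry over, in the same direction. For this change, the expected step is a 1.5-fold lower number from compound 2 to compound 4 (0.19 log units; within the scatter). Compound 4 is estimated at 6000 nM, with a likely range from 2500 nM to 14000 nM.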

Compound 4, half-maximal inhibitory concentration: 65800 nM
For compound 4 the middle estimate is 11-fold (1.04 log units) below the measured one; the whole stated range lies below it.
By their numbers in this assay, from the lowest: compound 3; then compounds 2 and 1 (each within the scatter of the next); then compound 4.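

In this assay the 2-chloro-6-fluorophenyl group brings a 7.2-fold higher number from compound 2 to compound 4 (0.85 log units; beyond the scatter) and a 5.8-fold higher number from compound 1 to compound 4 (0.77 log units; beyond the scatter) and also a 20-fold higher number from compound 3 to compound 4 (1.30 log units; beyond the scatter) so compound 4 is the weakest of the four, and the aromatic group at this position now clearly moves the number in both directions. Having more than one substituent on this ring therefore does not by itself give a lower number: compound 3 and compound 4 both have more than one, yet they stand at opposite ends of the order, so the identity of the substituents matters and not just their count. Nothing available here explains why this group gives so much higher a number than the others.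

The compounds shown leave open whether the rise belongs to the fluorine, to the chlorine or only to the two together, which 2-chlorophenyl and 2-fluorophenyl groups would help to separate. They also leave open whether halogens as such go against the result of compound 3, a question that 2,6-dimethylphenyl and 2,6-dichlorophenyl groups on the same core could address.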